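Replacing the phenyl of compound 2 with carbamoyl

This account rests on a few compounds, and the source may have more. Where it says the series, first, only, none or still open, it means among the compounds named here.

Measured so far:
compound 1 `COC1=CC(=O)c2c(c(CO)c(C3CC3)n2C)C1=O`: 540000 nM
compound 2 `COC1=CC(=O)c2c(c(COc3ccccc3)c(C)n2C)C1=O`: 12000 nM
compound 3 `COC1=CC(=O)c2c(c(COc3cccc(NC(C)=O)c3)c(C)n2C)C1=O`: 3700 nM

These three values come from a functional assay on V79-379A cells (Cricetulus griseus) for cytotoxicity, read by MTT assay, in the presence of a further agent that is not named here; a higher number here means a weaker inhibitor, a lower number a stronger inhibitor. Compound 2 holds the second highest of the three numbers, with compound 3 lower at 3700 nM and compound 1 far higher at 540000 nM.

Compound 4 `COC1=CC(=O)c2c(c(COC(N)=O)c(C)n2C)C1=O` has not yet been measured. It differs from compound 2 by one change: carbamoyl in place of phenyl on an oxygen on a saturated carbon. In words, carbamoyl stands in place of phenyl on an oxygen on a saturated carbon.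

Among the compounds with values here, only one measured step bears on this change, and only indirectly: a 3.2-fold lower number from compound 2 to compound 3 (0.51 log units; beyond the scatter). That step, acetamido in place of hydrogen on an aromatic carbon, alters the ring that compound 4 loses, but it does not show what losing the ring does. Within the data shown here, no measured compound carries carbamoyl. In this assay a modest step towards a higher number is therefore expected, though the direction is uncertain. The wide spread set by compound 1 at 540000 nM calls for a broad range. The expected step is a 2.1-fold higher number from compound 2 to compound 4 (0.32 log units; beyond the scatter). The estimate for compound 4 is 25000 nM, with an expected range of 5000 nM to 120000 nM.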

Compound 4, half-maximal inhibitory concentration: 25000 nM
The estimate for compound 4 equals the measured number at the digits printed; low and high end bracket the measured number.
By their numbers in this assay, from the lowest: compound 3; then compound 2; then compound 4; then compound 1.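

In this assay, carbamoyl in place of phenyl on an oxygen on a saturated carbon gives a 2.1-fold higher number from compound 2 to compound 4 (0.32 log units; beyond the scatter), so this position tolerates the complete loss of the aromatic ring with only a modest shift in the number. Within the data shown here, until this result, the only step bearing on the group at this oxygen was a change on the phenyl ring itself, a 3.2-fold lower number from compound 2 to compound 3 (0.51 log units; beyond the scatter), which left the ring in place and moved the number the other way. Among these compounds, the exchange of phenoxy for carbamoyloxy therefore adds the first view of a group with no ring and fewer heavy atoms here, but no evidence at hand accounts for the size or direction of the step.

This single exchange removes the ring and brings in carbamoyl together, and the compounds shown do not separate the two contributions. Also open, as far as these compounds go, is how a methyl, an acetyl or a benzyl group on this same oxygen would stand in this assay, and whether an amine on the phenyl ring would lower the number as acetamido does.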